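This account rests on a few compounds, and the source may have more. Where it says the series, first, only, none or still open, it means among the compounds named here.

In an ADME assay on microsomes from liver (Homo sapiens) for metabolic stability, with a stated time of 10 min (on this read-out higher numbers stand for a more stable compound and lower numbers for a less stable compound), compound 1 `O=C1NC(=O)C2(CCC(C(=O)N3CC[C@](c4ccc(C(F)(C(F)(F)F)C(F)(F)F)cc4)(S(=O)(=O)c4ccc(F)cc4)C3)CC2)N1` gives 84%; 93% (2 entries), and the several entries of compound 1 in this assay, 84%; 93% (2 entries) shows how far repeat readings of a single compound can lie apart. Compound 2 `O=C(N1CC[C@](c2ccc(C(F)(C(F)(F)F)C(F)(F)F)cc2)(S(=O)(=O)c2ccc(F)cc2)C1)C1(F)CCS(=O)(=O)CC1` gives 100%, and compound 3 `O=C(N1CC[C@](c2ccc(C(F)(C(F)(F)F)C(F)(F)F)cc2)(S(=O)(=O)c2ccc(F)cc2)C1)C1(O)CCS(=O)(=O)CC1` gives 100%, so compound 3 stands level with compound 2. Compound 4 `O=C(N1CC[C@](c2ccc(C(F)(C(F)(F)F)C(F)(F)F)cc2)(S(=O)(=O)c2ccc(F)cc2)C1)C1(CO)CCS(=O)(=O)CC1` has not yet been measured. It carries hydroxymethyl in place of hydroxy on a saturated ring carbon, three ring bonds from the ring sulfur of a six-membered non-aromatic ring: hydroxymethyl in place of hydroxy on a saturated ring carbon. Among the compounds with values here, one measured step bears on this change, the exchange at that same ring carbon that puts hydroxy in place of fluoro, no change at the digits printed from compound 2 to compound 3 (within the scatter). Within the data shown here, with only that step to go on, no movement beyond the scatter is expected in this assay, in either direction. The expected step is a number 4 percentage points lower from compound 3 to compound 4 (within the scatter). For compound 4 the estimate is 96%, with an expected range from 84% to 100%.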

Compound 4, percent of the compound remaining: 75%
Compound 4: middle estimate off by 21 percentage points, on the high side, and the stated range ends above it.
By their numbers in this assay, from the lowest: compound 4; then compounds 2 and 3 (each within the scatter of the next).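

Fluoro and hydroxy on this saturated ring carbon had read alike in this assay, which made the position look tolerant of change, but hydroxymethyl shows that it is not, with a number 25 percentage points lower from compound 3 to compound 4 (beyond the scatter) and, set against fluoro, a number 25 percentage points lower from compound 2 to compound 4 (beyond the scatter). Hydroxy and hydroxymethyl have the same count of hydrogen-bond donors and acceptors, so that count alone does not settle the read-out at this position. The fall is also wider than the gap between repeat readings of a single compound: the several entries of compound 1 in this assay, 84%; 93% (2 entries)

Whether the fall comes with the extra carbon alone or also depends on the hydroxy group cannot be told from these compounds. A methyl, methoxymethyl or aminomethyl group on the same ring carbon would help to separate the two.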